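A few compounds are considered here, and "the series" means these few. Any claim that something is new, unique, unknown or untested is made for them only; others in the source may bear on it.

Within the data shown here, compound 2 `COc1cc(N2C(=O)[C@@H](Oc3ccccc3)[C@H]2c2ccc(N=[N+]=[N-])cc2)cc(OC)c1OC` is one of only two compounds measured in a functional assay on MCF7 cells (Homo sapiens) for antiproliferative activity, read by MTT assay, with stated times of 24 h and 72 h; on this read-out higher numbers stand for weaker inhibition and lower numbers for stronger inhibition; in that assay compound 2 gives 23000 nM. Compound 1 `COc1cc(N2C(=O)[C@@H](Oc3ccccc3)[C@H]2c2ccc(N(C)C)cc2)cc(OC)c1OC` gives 31000 nM in this assay, and the step of a 1.3-fold lower number from compound 1 to compound 2 (0.13 log units; within the scatter) leaves the two numbers within the scatter of each other. Compound 3 `COc1cc([N+](=O)[O-])c([C@@H]2[C@H](Oc3ccccc3)C(=O)N2c2cc(OC)c(OC)c(OC)c2)cc1O` is not yet measured; it differs from compound 2 by a group of 12 heavy atoms (7 carbon, 1 nitrogen, 4 oxygen; one six-membered aromatic ring of carbon only) in place of a group of 9 heavy atoms (6 carbon, 3 nitrogen; one six-membered aromatic ring of carbon only), on a saturated ring carbon. Among the measured compounds shown here, the single measured step touches a different part of the molecule and offers little guidance for this change. Compound 3 is therefore expected to show no change at the digits printed from compound 2 to compound 3 (within the scatter), with no step beyond the scatter foreseen. The estimate for compound 3 in this assay is 23000 nM, ranging from 5000 nM to 90000 nM.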

Compound 3, half-maximal inhibitory concentration: 59000 nM
Compound 3: middle estimate off by 2.6-fold (0.41 log units), on the low side; the range from low to high includes it.
By their numbers in this assay, from the lowest: compounds 2, 1 and 3 (each within the scatter of the next, the first and the last beyond it).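

Among these compounds, at this saturated ring carbon of the four-membered ring, placing an aromatic ring with nitro, hydroxy and methoxy groups in this assay gives a 2.6-fold higher number from compound 2 to compound 3 (0.41 log units; beyond the scatter) and so the first step beyond the scatter. The same replacement gives a 1.9-fold higher number from compound 1 to compound 3 (0.28 log units; within the scatter) and stays within the scatter, so the change stands out only against the 4-azidophenyl group. No measurement bearing on the cause of this step is available. The compounds shown leave open which of the nitro, hydroxy or methoxy groups on that ring matters, and whether an amine in place of the nitro group or a carboxylic acid in place of the hydroxy group would shift the number.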